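This account rests on a few compounds, and the source may have more. Where it says the series, first, only, none or still open, it means among the compounds named here.

Working notes on the series.

Compound 1 `N=C(NCCCc1c[nH]cn1)NCCC(c1ccc(F)cc1)c1ccccn1` and compound 2 `N=C(NCCCc1c[nH]cn1)NCCC(c1cccc(F)c1)c1ccccn1` share one core and differ only in the fluorophenyl group. In a functional assay on cardiac atrium for agonist activity at histamine H2 receptor (Cavia porcellus) (a higher number here means a larger maximal response, a lower number a smaller maximal response), compound 1 gives 1. In this assay compound 2 gives 1. The step of no change at the digits printed from compound 1 to compound 2 (within the scatter) shows that moving the fluoro from 4-fluorophenyl to 3-fluorophenyl leaves the maximal response where it was. Compound 2 therefore stands level with compound 1 at the digits shown, and both reach the full response of the reference agonist.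

Compound 3 `N=C(NCCCc1c[nH]cn1)NCCC(c1cccc(C(F)(F)F)c1)c1ccccn1` is the next member, not yet measured. The change from compound 2 is trifluoromethyl in place of fluoro on an aromatic carbon. Among the measured compounds shown here, no measured step exchanges one substituent for a larger one on this ring; the only step on record, from compound 1 to compound 2, moved a fluoro between ring positions and stayed within the scatter. The expectation for compound 3 rests on that single step, and the step a number 0.050 lower from compound 2 to compound 3 (within the scatter) is estimated to stay within the scatter, as the earlier one did. For compound 3 the value expected in this assay is 0.95, with the range 0.7 to 1.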

Compound 3, intrinsic activity: the largest response reached, as a fraction of the reference agonist's: 1
Beside the measured number, compound 3's estimate is 0.050 below it, and the stated range covers the measured number.
By their numbers in this assay, from the lowest: compounds 1, 2 and 3 (each within the scatter of the next).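

Working notes, continued.

In this assay, trifluoromethyl in place of fluoro gives no change at the digits printed from compound 2 to compound 3 (within the scatter), so this place, on an aromatic carbon meta to a large group, now carries 4 heavy atoms instead of 1 with the maximal response held, whereas the earlier pair showed only a fluoro moved around the ring. Changing the position and the group together, 3-(trifluoromethyl)phenyl in place of 4-fluorophenyl, also gives no change at the digits printed from compound 1 to compound 3 (within the scatter), so in these three compounds neither the fluoro nor its placement is required for the full response. Nothing on record bears on why the maximal response holds across these changes.

The compounds shown leave open whether an amine or a carboxylic acid at this place would keep the maximal response in this assay, since fluoro and trifluoromethyl are the only groups seen there. From the compounds shown here alone, the read-out gives only the largest response, so how much of each compound is needed to reach it stays open, as does the effect of a longer chain on the shared core.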